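A few compounds are considered here, and "the series" means these few. Any claim that something is new, unique, unknown or untested is made for them only; others in the source may bear on it.

Compound 1 `COc1ccc(Oc2ccc(C(C)C)cc2-c2ccsc2S(=O)(=O)NCCNC(=S)Nc2ccc([N+](=O)[O-])cc2)cc1OC` and compound 3 `CC(C)c1ccc(Oc2ccc(O)c(O)c2)c(-c2ccsc2S(=O)(=O)NCCNC(=S)Nc2ccc([N+](=O)[O-])cc2)c1` share a core and differ only at one point; compound 2 `O=C(Nc1cccc([N+](=O)[O-])c1)N1CCN(S(=O)(=O)c2sccc2-c2ccccc2Oc2ccc(O)c(O)c2)CC1` and compound 4 `COc1ccc(Oc2ccccc2-c2ccsc2S(=O)(=O)N2CCN(C(=O)Nc3cccc([N+](=O)[O-])c3)CC2)cc1OC` share another core, and the difference between the two cores is not broken down here. In a functional assay on HeLa cells (Homo sapiens) for inhibition, read by CCK-8 assay, with a stated time of 48 h (a lower number here means a stronger inhibitor, a higher number a weaker inhibitor), compound 1 gives 11900 nM. For compound 3 the result in this assay is only a limit of the assay, > 20000 nM. For compound 2 the result in this assay is likewise only a limit, > 20000 nM. The change from compound 3 to compound 1 is 3,4-dimethoxyphenyl in place of 3,4-dihydroxyphenyl on an oxygen on an aromatic ring, and it gave an at least 1.6-fold lower number from compound 3 to compound 1 (0.22 log units; that floor lies within the scatter); because of the limit of > 20000 nM in this assay, at which 2 of the 3 values shown sit, the true size of that step is not known. The same change, (3,4-dimethoxyphenyl in place of 3,4-dihydroxyphenyl on an oxygen on an aromatic ring), is made from compound 2 to compound 4, at a place described in the same words. The step is expected to be an at least 1.3-fold lower number from compound 2 to compound 4 (0.12 log units; that floor lies within the scatter), resting on the measured value of compound 1 11900 nM and on the earlier step. Compound 4 is therefore estimated at 15000 nM, with a range from 6000 nM to 40000 nM.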

Compound 4, half-maximal inhibitory concentration: > 50000 nM
Compound 4 ended at the assay's limit; the forecaster's own chance of this, stated with the estimate: 50%; at least 3.3-fold (0.52 log units) between middle value and limit.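

In this assay compound 2 stands only at a limit, > 20000 nM. Compound 4 also stands only at a limit, > 50000 nM, and no step can be read between compound 2 and compound 4. The compounds shown leave open how far 3,4-dimethoxyphenyl in place of 3,4-dihydroxyphenyl shifts the number on either core.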